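Swapping the Aryl Amine on a Shared Core

The source may hold more compounds than are shown below. What is called first, only, known or untested is meant among the compounds shown, and "the series" means these compounds.

Compound 1 `O=C(CSc1nc(Nc2ccccc2)c2ccccc2n1)Nc1ccc(C(F)(F)F)cc1` and compound 2 `C=CC(=O)Nc1cccc(NC(=O)CSc2nc(Nc3cccc(Cl)c3)c3ccccc3n2)c1` share a core and were tested in a functional assay on NCI-H1975 cells (Homo sapiens) for inhibition, read by MTT assay, with a stated time of 72 h; on this read-out higher numbers stand for weaker inhibition and lower numbers for stronger inhibition. Compound 1 gives 11700 nM and compound 2 gives 9460 nM, which is the smaller of the two numbers, yet the gap to compound 1 lies within the scatter, so the two are not told apart. Compound 3 `C=CC(=O)Nc1cccc(NC(=O)CSc2nc(Nc3ccc(C(F)(F)F)cc3)c3ccccc3n2)c1` is not yet measured and differs from compound 2 by 4-(trifluoromethyl)phenyl in place of 3-chlorophenyl on a nitrogen on an aromatic ring. Compound 1 already carries the 4-(trifluoromethyl)phenyl group and gives 11700 nM, so no step beyond the scatter is expected. The expected step from compound 2 to compound 3 is a 1.2-fold higher number from compound 2 to compound 3 (0.07 log units; within the scatter). For compound 3 the estimate is 11000 nM, within 5000 nM to 25000 nM.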

Compound 3, half-maximal inhibitory concentration: 12900 nM
Compound 3: middle estimate off by 1.2-fold (0.07 log units), on the low side; measured number inside the range.
By their numbers in this assay, from the lowest: compounds 2, 1 and 3 (each within the scatter of the next).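

Within the data shown here, at the nitrogen on an aromatic ring, the change to 4-(trifluoromethyl)phenyl from 3-chlorophenyl gives the first one-place comparison in this assay, with a 1.4-fold higher number from compound 2 to compound 3 (0.13 log units; within the scatter). The two groups are therefore not told apart in these cells, whereas compounds 1 and 2 differ in more than one place and could not show this. No measurement at hand explains the result. As far as these compounds go, both groups are substituted phenyl rings, so it remains open whether a pyridine ring or a cyclohexyl ring in this place would give a step beyond the scatter.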